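Amide nitrogen substituents on the shared core

The source may report more compounds than this note shows. Statements on the series, on what has been measured and on what is new or still open speak of the compounds shown alone.

Measured compounds:
compound 1 `CCn1c(C(=O)NCCN(C)C)ccc1C(CC)(CC)c1ccc(OCCC(O)(CC)CC)c(C)c1`: 240 nM
compound 2 `CCOC(=O)C(CC(=O)OC)NC(=O)c1ccc(C(CC)(CC)c2ccc(OCCC(O)(CC)CC)c(C)c2)n1CC`: > 50000 nM
compound 3 `CCC(C)C(NC(=O)c1ccc(C(CC)(CC)c2ccc(OCCC(O)(CC)CC)c(C)c2)n1CC)C(=O)O`: 2620 nM

In a functional assay on HepG2 cells (Homo sapiens) for antiproliferative activity, read by MTT assay, with a stated time of 48 h (a higher number here means a weaker inhibitor, a lower number a stronger inhibitor), compound 1 gives 240 nM, the lowest of the two numbers shown; its nearest neighbour is compound 3 at 2620 nM. Compound 2 reaches only the limit > 50000 nM (the limit of > 50000 nM in this assay, at which 1 of the 3 values shown sits).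

Compound 4 `CCn1c(C(=O)NC(CC(=O)O)C(=O)OC)ccc1C(CC)(CC)c1ccc(OCCC(O)(CC)CC)c(C)c1` carries a group of 9 heavy atoms (5 carbon, 4 oxygen; no ring) in place of a group of 5 heavy atoms (4 carbon, 1 nitrogen; no ring), on an amide-type nitrogen. Going by the values given here, the steps that bear on it are an at least 200-fold higher number from compound 1 to compound 2 (2.31 log units; beyond the scatter) and an 11-fold higher number from compound 1 to compound 3 (1.04 log units; beyond the scatter), both upward and large, while an at least 19-fold lower number from compound 2 to compound 3 (1.28 log units; beyond the scatter) shows that a free carboxylic acid on this nitrogen sits far from the limit. Compound 4 holds one carboxylic acid and one ester, so a large upward step is expected in this assay, a 33-fold higher number from compound 1 to compound 4 (1.52 log units; beyond the scatter), landing between the two. Compound 4 is estimated at 8000 nM, range 2000 nM to 40000 nM.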

Compound 4, half-maximal inhibitory concentration: 10700 nM
Compound 4: middle estimate off by 1.3-fold (0.13 log units), on the low side; the range from low to high includes it.
By their numbers in this assay, from the lowest: compound 1; then compound 3; then compound 4. At a limit, above all of these: compound 2.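

In this assay, the substituent of compound 4, with its carboxylic acid and ester, stays short of the limit yet gives a 45-fold higher number from compound 1 to compound 4 (1.65 log units; beyond the scatter), so the loss of 2-(dimethylamino)ethyl on the amide-type nitrogen is large here too. Substituents without the amine also separate from one another: a 4.1-fold higher number from compound 3 to compound 4 (0.61 log units; beyond the scatter), and an at least 4.6-fold lower number from compound 2 to compound 4 (0.66 log units; beyond the scatter). Compound 2 stands at a limit, so its step is a bound only: the limit of > 50000 nM in this assay, at which 1 of the 4 values shown sits.

From the compounds shown here alone, whether the amine itself or the entering acid and ester groups drive these steps stays open. A longer chain ending in an amine, or a neutral hydroxyethyl group, on this nitrogen would separate the two.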